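From difluoromethyl to carbamoyl in a liver clearance test

A few compounds are considered here, and "the series" means these few. Any claim that something is new, unique, unknown or untested is made for them only; others in the source may bear on it.

Two related compounds have been measured so far in an in vitro ADME assay on microsomes from liver (Homo sapiens) for metabolic stability (on this read-out higher numbers stand for fast clearance and lower numbers for slow clearance), and they frame the question. Compound 1 `Fc1ccccc1Cc1nc(-c2nc(C(F)F)n[nH]2)n2ccccc12` gives 62 mL.min-1.g-1 here, the higher of the two numbers. Compound 2 `Fc1ccccc1Cc1nc(-c2nc(C(F)(F)F)n[nH]2)n2cccnc12` gives 17 mL.min-1.g-1 by comparison, a gap beyond the usual scatter, though no single change links the two.

Compound 3 `NC(=O)c1n[nH]c(-c2nc(Cc3ccccc3F)c3ccccn23)n1` keeps the core of compound 1. The difference is carbamoyl in place of difluoromethyl on an aromatic carbon and in words it is carbamoyl in place of difluoromethyl on an aromatic carbon, on the five-membered aromatic ring with 3 nitrogen. Among the compounds with values here, no measured pair shows this swap alone, so what follows is a judgement. The expected change is a 2.8-fold lower number from compound 1 to compound 3 (0.45 log units; beyond the scatter) towards slower clearance, a step beyond the scatter. For compound 3 the estimated clearance is 22 mL.min-1.g-1 with an expected range of 8 mL.min-1.g-1 to 50 mL.min-1.g-1 until it is measured.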

Compound 3, intrinsic clearance in microsomes: < 8 mL.min-1.g-1
Compound 3 gave a limit, no number; the forecaster's own chance of this, stated with the estimate: 10%; at least 2.7-fold (0.43 log units) between middle value and limit.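

In this assay, within the data shown here, carbamoyl in place of difluoromethyl on this aromatic carbon gives the first comparison that changes one place only, with the rest of the core of compound 1 kept: an at least 7.7-fold lower number from compound 1 to compound 3 (0.88 log units; beyond the scatter) is the step. The earlier gap between compound 1 and compound 2 could not show this, as those two differ in more than one place, whereas here this single position alone moves clearance beyond the scatter. Compound 3 gave a limit of the assay and not a number, so the step is a minimum: the limit of < 8 mL.min-1.g-1 in this assay, at which 1 of the 3 values shown sits.

Going by these compounds, how far compound 3 lies past its limit stays open, as does whether the same swap would act alike on the core of compound 2. A carboxylic acid, an amine or a nitrile on this same carbon could show how much of the step is specific to carbamoyl.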